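The source may report more compounds than this note shows. Statements on the series, on what has been measured and on what is new or still open speak of the compounds shown alone.

Compound 1 `O=C(NC1CCN(Cc2ccc(Cl)cc2)CC1)c1cccc2ccccc12` gives 43 nM in an assay on isolated protein for displacement of a labelled ligand from D(4) dopamine receptor (Homo sapiens) (a lower number here means a stronger inhibitor, a higher number a weaker inhibitor), the lowest of the three numbers shown; compound 2 `O=C(NC1CCN(Cc2cccc(C(F)(F)F)c2)CC1)c1cccc2ccccc12` gives 119 nM and compound 3 `Cc1ccccc1CN1CCC(NC(=O)c2cccc3ccccc23)CC1` gives 155 nM. Compound 4 `Cc1ccc(CN2CCC(NC(=O)c3cccc4ccccc34)CC2)cc1` differs from compound 1 by a single change: methyl in place of chloro on an aromatic carbon. Among the compounds with values here, no measured step exchanges methyl for chloro at this place, but the two steps that alter the benzyl ring of compound 1, a 2.8-fold higher number from compound 1 to compound 2 (0.44 log units; beyond the scatter) and a 3.6-fold higher number from compound 1 to compound 3 (0.56 log units; beyond the scatter), both moved the number modestly upward, and between those two products the difference was only a 1.3-fold higher number from compound 2 to compound 3 (0.11 log units; within the scatter). A modest upward step is therefore expected for compound 4, a 2.1-fold higher number from compound 1 to compound 4 (0.32 log units; beyond the scatter). Compound 4 is thus estimated at 90 nM, within a range of 35 nM to 230 nM.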

Compound 4, inhibition constant: 69 nM
Compound 4: middle estimate off by 1.3-fold (0.12 log units), on the high side; low and high end bracket the measured number.
By their numbers in this assay, from the lowest: compounds 1, 4, 2 and 3 (each within the scatter of the next, the first and the last beyond it).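

In this assay, the step of a 1.6-fold higher number from compound 1 to compound 4 (0.21 log units; within the scatter) shows that methyl and chloro on this aromatic carbon, para to a large group, cannot be told apart. Where the methyl sits does count, with a 2.2-fold lower number from compound 3 to compound 4 (0.35 log units; beyond the scatter) as 4-methylphenyl replaces 2-methylphenyl. Against 3-(trifluoromethyl)phenyl, the step of a 1.7-fold lower number from compound 2 to compound 4 (0.24 log units; within the scatter) separates nothing either.

On these data alone, whether a methoxy group, an amine or a carboxylic acid at this place would keep the number in the same range stays open. Nothing available explains these results.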